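The source may hold more compounds than are shown below. What is called first, only, known or untested is meant among the compounds shown, and "the series" means these compounds.

Measured so far in a functional assay on CCRF-CEM cells (Homo sapiens) for cytotoxicity, read by XTT assay, with a stated time of 3 days; on this read-out lower numbers stand for stronger inhibition and higher numbers for weaker inhibition:
- compound 1 `OC[C@H]1O[C@@H](n2cc(F)c3c(-c4ccco4)ncnc32)[C@H](O)[C@@H]1O` gives 1400 nM
- compound 2 `OC[C@H]1O[C@@H](n2cc(F)c3c(-c4cccs4)ncnc32)[C@H](O)[C@@H]1O` gives 270 nM
- compound 3 `OC[C@H]1O[C@@H](n2cc(F)c3c(-c4ccoc4)ncnc32)[C@H](O)[C@@H]1O` gives 1000 nM

In this assay compound 2 has the lowest number of the three at 270 nM. It is separated from the other two by more than the scatter, as a 5.2-fold lower number from compound 1 to compound 2 (0.71 log units; beyond the scatter) and a 3.7-fold higher number from compound 2 to compound 3 (0.57 log units; beyond the scatter) show.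

The next entry is compound 4 `OC[C@H]1O[C@@H](n2cc(F)c3c(-c4ccsc4)ncnc32)[C@H](O)[C@@H]1O`, with thiophen-3-yl in place of thiophen-2-yl on an aromatic carbon of the shared core. The two have the same atoms, joined differently: thiophen-3-yl in place of thiophen-2-yl on an aromatic carbon.

Within the data shown here, the closest precedent is the matching change among the furans, a 1.4-fold lower number from compound 1 to compound 3 (0.15 log units; within the scatter), which stays within the scatter. The two larger steps, a 5.2-fold lower number from compound 1 to compound 2 (0.71 log units; beyond the scatter) and a 3.7-fold higher number from compound 2 to compound 3 (0.57 log units; beyond the scatter), both exchange furan for thiophene or the reverse, and compound 4 makes no such exchange, so they bear on it less directly. Among the measured compounds shown here, the argument therefore rests on a single pair, and no measured step tests this change within the thiophenes.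

The expected 1.1-fold higher number from compound 2 to compound 4 (0.05 log units; within the scatter) is small, with no step beyond the scatter anticipated and no firm direction. The estimate for compound 4 is 300 nM, with an expected range from 110 nM to 800 nM.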

Compound 4, half-maximal inhibitory concentration: 560 nM
For compound 4 the middle estimate is 1.9-fold (0.27 log units) below the measured one; low and high end bracket the measured number.
By their numbers in this assay, from the lowest: compound 2; then compounds 4, 3 and 1 (each within the scatter of the next, the first and the last beyond it).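

Working notes on the series: in this assay the attachment point of the thiophene counts on this aromatic carbon, since a 2.1-fold higher number from compound 2 to compound 4 (0.32 log units; beyond the scatter) is a modest step with the same atoms joined differently, whereas the matching furan change, a 1.4-fold lower number from compound 1 to compound 3 (0.15 log units; within the scatter) stays within the scatter. The advantage of thiophene over furan also depends on attachment: a 5.2-fold lower number from compound 1 to compound 2 (0.71 log units; beyond the scatter) is beyond the scatter for the 2-yl pair, but a 1.8-fold lower number from compound 3 to compound 4 (0.25 log units; within the scatter) is within it for the 3-yl pair, and the cross-comparison a 2.5-fold lower number from compound 1 to compound 4 (0.40 log units; beyond the scatter) is again a modest step beyond the scatter. No supporting measurement is available to explain these differences.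

Still open, as far as these compounds go, is how a phenyl ring, a pyridine ring or a dimethylamino group on this carbon would compare with thiophen-2-yl, and whether any such group would go beyond compound 2 by more than the scatter. Also open, from the compounds shown here alone, is whether the dependence on attachment point would persist with a methyl group on the thiophene ring, or with chlorine in place of the fluorine on the shared core.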